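The source may hold more compounds than are shown below. What is called first, only, known or untested is meant among the compounds shown, and "the series" means these compounds.

Measured compounds:
- compound 1 `CC(C)C[C@@H]1NC(=O)[C@H](CCCNC(=N)N)NC(=O)[C@H](CCCCN)NC(=O)[C@H](CC(=O)O)NC(=O)[C@H](CCCCN)NC(=O)CCNC1=O`: 1650 nM
- compound 2 `CCCC[C@@H]1NC(=O)[C@H](CCCNC(=N)N)NC(=O)[C@H](CCCCN)NC(=O)[C@H](CC(=O)O)NC(=O)[C@H](CCCCN)NC(=O)CCNC1=O`: 378 nM

Among the measured compounds shown here, in an assay on COS-7 cells for inhibition of disintegrin and metalloproteinase domain-containing protein 8 (Homo sapiens), read by ELISA, with a stated time of 6 h (a lower number here means a stronger inhibitor, a higher number a weaker inhibitor), compound 1 gives the higher of the two numbers, with compound 2 the nearer neighbour; the one measured step, a 4.4-fold lower number from compound 1 to compound 2 (0.64 log units; beyond the scatter), concerns the side chain on the saturated ring carbon and nothing else.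

Compound 3 `CC(C)C[C@@H]1NC(=O)[C@H](CCCNC(=N)N)NC(=O)[C@H](CCCC[N+](C)(C)C)NC(=O)[C@H](CC(=O)O)NC(=O)[C@H](CCCCN)NC(=O)CCNC1=O` keeps that side chain of compound 1 unchanged and differs elsewhere: a group of 4 heavy atoms (3 carbon, 1 nitrogen; no ring) in place of one nitrogen atom, on a saturated chain carbon, four bonds along the chain from a saturated ring carbon. For the measured compounds named here, no measured step touches this part of the shared core, so the only measured step, from compound 1 to compound 2, does not bear on the change and gives no direction for it. Going by the values given here, with nothing comparable in hand, the working expectation for this assay is a step that stays within the scatter, that is, a 1.2-fold higher number from compound 1 to compound 3 (0.08 log units; within the scatter), with a wide range to reflect that no measured pair informs it.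

Compound 3 is therefore expected to give about 2000 nM in this assay, with a range from 600 nM to 7000 nM.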

Compound 3, half-maximal inhibitory concentration: > 10000 nM
Compound 3: only a limit was reported; the forecaster's own chance of this, stated with the estimate: 10%; at least 5.0-fold (0.69 log units) between middle value and limit.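

The position on a saturated chain carbon, four bonds along the chain from a saturated ring carbon, is not indifferent in this assay: replacing the amino group there with the group of 4 heavy atoms (3 carbon, 1 nitrogen) gives an at least 6.0-fold higher number from compound 1 to compound 3 (0.78 log units; beyond the scatter). The exchange removes the hydrogen-bond donor and acceptor counted on the amino group and adds a net charge of +1, and this single step cannot separate these differences from one another. The result for compound 3 is a limit and not a number, so the step has no upper bound: the limit of > 10000 nM in this assay, at which 1 of the 3 values shown sits.

Open, going by these compounds, is which part of the change carries the step, a question that a methylamine, a dimethylamine or an acetamide at the same place would help to divide. Also open, on these data alone, is whether the same replacement gives a comparable step on the core of compound 2, and whether a shorter or longer chain carrying the amino group is tolerated at this place.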